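Side-chain amine change from compound 3 to compound 4

A few compounds are considered here, and "the series" means these few. Any claim that something is new, unique, unknown or untested is made for them only; others in the source may bear on it.

Measured in a functional assay on MCF7 cells (Homo sapiens) for cytotoxicity, read by MTT assay, with a stated time of 72 h; a higher number here means a weaker inhibitor, a lower number a stronger inhibitor:
- compound 1 `O=C1c2c[n+]([O-])c3ccccc3c2C(=O)c2c1c1ccccc1n2CCCCN1CCNCC1` gives 12000 nM
- compound 2 `CCCCN1CCN(CCCCn2c3c(c4ccccc42)C(=O)c2c[n+]([O-])c4ccccc4c2C3=O)CC1` gives 6900 nM
- compound 3 `CN(C)CCCCn1c2c(c3ccccc31)C(=O)c1c[n+]([O-])c3ccccc3c1C2=O` gives 220 nM

Compound 3 has the lowest number of the three, and both of its steps to the others lie beyond the scatter. The next compound, compound 4 `CN1CCN(CCCCCn2c3c(c4ccccc42)C(=O)c2c[n+]([O-])c4ccccc4c2C3=O)CC1`, has not been measured. The change is (4-methylpiperazin-1-yl)methyl in place of dimethylamino on a saturated chain carbon, four bonds along the chain from an aromatic nitrogen.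

Two large measured steps bear most directly on this change: a 55-fold lower number from compound 1 to compound 3 (1.74 log units; beyond the scatter) and a 31-fold lower number from compound 2 to compound 3 (1.50 log units; beyond the scatter). Both run from a compound with a piperazine ring to the dimethylamino compound, whereas compound 4 goes the opposite way. The group on the ring nitrogen shows no effect so far, with a 1.7-fold lower number from compound 1 to compound 2 (0.24 log units; within the scatter). Among the compounds with values here, no measured step tests the change in chain length, so the expectation carries extra uncertainty.

A large step towards a higher number is therefore expected in this assay, with an estimated size of a 23-fold higher number from compound 3 to compound 4 (1.36 log units; beyond the scatter). The estimate for compound 4 is 5000 nM, with an expected range of 1200 nM to 16000 nM.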

Compound 4, half-maximal inhibitory concentration: 1260 nM
Compound 4: middle estimate off by 4.0-fold (0.60 log units), on the high side; the measured number falls inside the stated range.
By their numbers in this assay, from the lowest: compound 3; then compound 4; then compounds 2 and 1 (each within the scatter of the next).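

In this assay, the (4-methylpiperazin-1-yl)methyl change costs less than the earlier piperazine compounds implied: a 5.7-fold higher number from compound 3 to compound 4 (0.76 log units; beyond the scatter) is a modest step, and compound 3 still holds the lowest number of the four. Compound 4 also separates from the other piperazine compounds, with a 5.5-fold lower number from compound 2 to compound 4 (0.74 log units; beyond the scatter) and a 9.5-fold lower number from compound 1 to compound 4 (0.98 log units; beyond the scatter), so a piperazine ring at this chain position is compatible with a number well below those of compound 1 and compound 2, although these steps change both the ring's nitrogen group and the chain length. No supporting data bear on why these steps differ in size.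

The compounds shown do not separate the longer chain of compound 4 from its methyl group on the ring nitrogen, and the pairs that would do so are the chain of compound 3 ending in 4-methylpiperazin-1-yl and the chain of compound 4 ending in dimethylamino. Also open, on these data alone, is how other terminal amines, such as morpholine or pyrrolidine, would compare with dimethylamino at this position.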